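This account rests on a few compounds, and the source may have more. Where it says the series, first, only, none or still open, it means among the compounds named here.

Compound 1 `COc1cc(-c2cc(/C=C/C(=O)c3ccc(Cl)c(Cl)c3)[nH]n2)cc(OC)c1OC`: in a functional assay on A549 cells (Homo sapiens) for inhibition, read by sulforhodamine B assay, with a stated time of 48 h (on this read-out lower numbers stand for stronger inhibition of growth and higher numbers for weaker inhibition of growth), compound 1 gives 18700 nM.
Compound 2 `COc1ccc(C(=O)/C=C/c2cc(-c3cc(OC)c(OC)c(OC)c3)n[nH]2)cc1OC`: in this assay compound 2 gives 1860 nM.

Within the data shown here, compound 2 stands lowest of these two numbers; its only neighbour is compound 1, separated from it by a 10-fold lower number from compound 1 to compound 2 (1.00 log units; beyond the scatter), a change of 3,4-dimethoxyphenyl for 3,4-dichlorophenyl on the carbonyl carbon.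

Compound 3 `COc1cc(-c2cc(/C=C/C(=O)c3ccc(F)c(F)c3)[nH]n2)cc(OC)c1OC` differs from compound 2 in one place: 3,4-difluorophenyl in place of 3,4-dimethoxyphenyl on a carbonyl carbon. Among the measured compounds shown here, the single measured step that bears on this change is a 10-fold lower number from compound 1 to compound 2 (1.00 log units; beyond the scatter), in which the 3,4-dichlorophenyl ring gave way to the 3,4-dimethoxyphenyl ring and the number fell well beyond the scatter. Compound 3 runs that exchange backwards, but with 3,4-difluorophenyl rather than 3,4-dichlorophenyl. A rise in the number is therefore expected for compound 3 in this assay, though fluorine is not chlorine, so a smaller movement than a 10-fold lower number from compound 1 to compound 2 (1.00 log units; beyond the scatter) seems the more likely outcome. Compound 3 is expected to give about 6000 nM, within 2000 nM to 20000 nM. That amounts to an expected step of a 3.2-fold higher number from compound 2 to compound 3 (0.51 log units; beyond the scatter).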

Compound 3, concentration for 50% growth inhibition: 2430 nM
Estimate against measurement, compound 3: 2.5-fold (0.39 log units) above; measured number inside the range.
By their numbers in this assay, from the lowest: compounds 2 and 3 (each within the scatter of the next); then compound 1.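

In this assay the exchange on the carbonyl carbon gives a 1.3-fold higher number from compound 2 to compound 3 (0.12 log units; within the scatter) and so leaves the number unchanged within the scatter, which shows that the 3,4-dimethoxyphenyl ring is not required at this position. The halogens do not behave alike here either: replacing 3,4-dichlorophenyl with 3,4-difluorophenyl gives a 7.7-fold lower number from compound 1 to compound 3 (0.89 log units; beyond the scatter) and brings the number level with that of compound 2, so the weak value of compound 1 cannot be attributed to halogen substitution as such. No evidence is available to explain this difference between the two halogenated rings.

As far as these compounds go, it remains open how a plain phenyl ring, or a ring carrying an amine or a carboxylic acid, would behave on this carbonyl carbon. The three compounds also leave open whether the pattern holds with any other substituent on this ring.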